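This account rests on a few compounds, and the source may have more. Where it says the series, first, only, none or still open, it means among the compounds named here.

In a functional assay on SK-OV-3 cells (Homo sapiens) for inhibition, read by sulforhodamine B assay, with a stated time of 48 h, tested at 0.01 uM (on this read-out higher numbers stand for a weaker effect at the one concentration tested and lower numbers for a stronger effect), compound 2 `COc1cc(Cl)cc(-c2nn(-c3cccc(NC(=O)Nc4cccc(C(F)(F)F)c4)c3)cc2-c2ccncc2)c1` gives 92%, the lowest of the two numbers at hand. In this assay compound 1 `COc1cc(Cl)cc(-c2nn(-c3cccc(NC(=O)Nc4ccc(Cl)c(C(F)(F)F)c4)c3)cc2-c2ccncc2)c1` gives 104%. Among the compounds with values here, the one step between them is a number 12 percentage points lower from compound 1 to compound 2 (beyond the scatter), a modest shift that lies beyond the scatter. Compound 3 `COc1cc(Cl)cc(-c2nn(-c3cccc(NC(=O)c4cccc(C(F)(F)F)c4)c3)cc2-c2ccncc2)c1` has not yet been measured in this assay. It differs from compound 2 in a single place: 3-(trifluoromethyl)phenyl in place of (3-(trifluoromethyl)phenyl)amino on a carbonyl carbon. Within the data shown here, no measured step bears on this kind of change; the only step known, a number 12 percentage points lower from compound 1 to compound 2 (beyond the scatter), concerns hydrogen in place of chloro on an aromatic carbon rather than the carbonyl carbon at which compound 3 changes. The numbers therefore give no ground to expect a step beyond the scatter in either direction in this assay. Compound 3 is expected to give 95%, with a range from 78% to 110%. The estimated step, a number 3 percentage points higher from compound 2 to compound 3 (within the scatter), is expected to stay within the scatter.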

Compound 3, a percentage reported as activity, at one concentration (the size of the read-out at that concentration, not a potency): 102%
Beside the measured number, compound 3's estimate is 7 percentage points below it; low and high end bracket the measured number.
By their numbers in this assay, from the lowest: compounds 2, 3 and 1 (each within the scatter of the next, the first and the last beyond it).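

In this assay, within the data shown here, the first change at the carbonyl carbon, 3-(trifluoromethyl)phenyl in place of (3-(trifluoromethyl)phenyl)amino, gives a number 10 percentage points higher from compound 2 to compound 3 (within the scatter), so losing the nitrogen and its hydrogen-bond donor leaves no effect that can be told from the scatter. The wider exchange, 3-(trifluoromethyl)phenyl in place of (4-chloro-3-(trifluoromethyl)phenyl)amino, gives a number 2 percentage points lower from compound 1 to compound 3 (within the scatter), and compound 3 thus stands within the scatter of both earlier compounds, although those two differ beyond it. Nothing available explains these steps.

On these data alone, whether a methylene group, a benzylamine or a morpholine on the carbonyl carbon would also stay within the scatter remains open. So does how a chloro group on the ring of compound 3 would read, and how any of these compounds behave at concentrations other than the single one tested.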